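Chloro on the phenyl of compound 3: expected effect

The source may report more compounds than this note shows. Statements on the series, on what has been measured and on what is new or still open speak of the compounds shown alone.

Working notes on three measured compounds and one awaiting measurement. Compound 1 `Cn1c(CN2CCN(c3ccc(C(F)(F)F)cc3)CC2)nc2ccccc21`, compound 2 `CCn1c(CN2CCN(c3nc(C(F)(F)F)ccc3Cl)CC2)nc2ccccc21` and compound 3 `Cn1c(CN2CCC(c3ccccc3)CC2)nc2ccccc21` share a core and differ in the group carried on the amine. In an assay on CHO cells with metabotropic glutamate receptor 2 (Homo sapiens) as the target, read by FLIPR (a higher number here means that more compound is needed for the effect, a lower number that less compound is needed), compound 1 gives 200 nM, compound 2 gives 63.1 nM, and compound 3 gives 200 nM. Compound 3 therefore stands level with compound 1 at the digits recorded, the two together giving the highest numbers of the three, while compound 2 sits at a number a good deal lower, beyond the usual scatter. No pair among these three differs in a single place, so no measured step is available to calibrate the change now under consideration.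

Compound 4 `Cn1c(CN2CCC(c3ccc(Cl)cc3)CC2)nc2ccccc21` is the next compound to be measured in this assay. It differs from compound 3 as follows: chloro in place of hydrogen on an aromatic carbon. With no measured step of this kind in the series, the expectation rests on the numbers of compound 3 alone, and the step of a 1.7-fold lower number from compound 3 to compound 4 (0.22 log units; within the scatter) is estimated to be small, toward a lower number, and most likely within the scatter. On that basis compound 4 is expected to give about 120 nM in this assay, with a plausible range from 45 nM to 320 nM.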

Compound 4, half-maximal effective concentration: 79.4 nM
Beside the measured number, compound 4's estimate is 1.5-fold (0.18 log units) above it; the range from low to high includes it.
By their numbers in this assay, from the lowest: compounds 2 and 4 (each within the scatter of the next); then compounds 1 and 3 (each within the scatter of the next).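

In this assay, among the compounds shown here, the change from phenyl to 4-chlorophenyl gives a 2.5-fold lower number from compound 3 to compound 4 (0.40 log units; beyond the scatter) and is the first measured step between compounds that differ in one place. It shows that this aromatic carbon, para to a large group, is not indifferent to substitution: a single chlorine in place of hydrogen moves the number by more than the usual scatter, toward less compound being needed for the effect. No measurement at hand accounts for this step, which therefore stands as an observation without an explanation.

On these data alone, whether the step belongs to chloro in particular remains open, as fluoro, methyl, methoxy or a nitrile at this same place would be needed to show how far it depends on the group that enters. Also open, as far as these compounds go, is whether chloro in place of hydrogen would give a step of similar size at the other aromatic carbons of this ring, or on the aromatic group carried on the amine in compound 1.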